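This account rests on a few compounds, and the source may have more. Where it says the series, first, only, none or still open, it means among the compounds named here.

In an ADME assay on A549 cells (Homo sapiens) for cytotoxicity, read by MTT assay (a higher number here means that more compound is tolerated, a lower number that less compound is tolerated), compound 1 `CCCCCCCCNc1ccn([C@H]2C[C@H](O)[C@@H](CO)O2)c(=O)n1` gives 90000 nM, compound 2 `CCCCCCCCCCCCNc1ccn([C@H]2C[C@H](O)[C@@H](CO)O2)c(=O)n1` gives 100000 nM and compound 3 `CCCCCCCCCCCCNc1nc(=O)n([C@H]2C[C@H](O)[C@@H](CO)O2)cc1C` gives 158000 nM, which places compound 2 within the scatter of both others. Compound 4 `O=c1nc(NCCCCc2ccccc2)ccn1[C@H]1C[C@H](O)[C@@H](CO)O1` carries phenyl in place of octyl on the chain of compound 2: phenyl in place of octyl on a saturated chain carbon, four bonds along the chain from a nitrogen on an aromatic ring. The closest measured change is on the chain, a 1.1-fold higher number from compound 1 to compound 2 (0.05 log units; within the scatter). The methyl change on an aromatic carbon, a 1.6-fold higher number from compound 2 to compound 3 (0.20 log units; within the scatter), bears on it less directly. Both steps stay within the scatter, so no step beyond the scatter is expected in this assay. Among the compounds with values here, no measured compound carries phenyl, which leaves the range wide. The estimated step is a 1.1-fold higher number from compound 2 to compound 4 (0.04 log units; within the scatter). For compound 4 the expected value is 110000 nM, with an estimated range of 50000 nM to 240000 nM.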

Compound 4, half-maximal cytotoxic concentration: 90000 nM
Compound 4: the middle estimate sits 1.2-fold (0.09 log units) above what was measured, and the stated range covers the measured number.
By their numbers in this assay, from the lowest: compounds 1, 4, 2 and 3 (each within the scatter of the next).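

In this assay, within the data shown here, the earlier compounds covered only saturated chains at this position. Phenyl in place of octyl now puts an aromatic ring on the chain, four bonds along the chain from a nitrogen on an aromatic ring, and the step stays within the scatter (a 1.1-fold lower number from compound 2 to compound 4 (0.05 log units; within the scatter)), as does phenyl in place of butyl (no change at the digits printed from compound 1 to compound 4 (within the scatter)). No measurement offers an explanation for this flat result. Open, going by these compounds, is whether an amine or a carboxylic acid at this place on the chain would leave the scatter. Also open, on these data alone, is whether a pyridine ring in place of phenyl would do so.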